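The source may report more compounds than this note shows. Statements on the series, on what has been measured and on what is new or still open speak of the compounds shown alone.

Measured in a functional assay on MGC-803 cells (Homo sapiens) for inhibition, read by sulforhodamine B assay, with a stated time of 72 h, tested at 10 uM; a higher number here means more inhibition at the concentration tested (going by the name of the read-out), a lower number less inhibition:

- compound 1, `Cc1cc(Nc2ccc(C(=O)/C=C/c3cccc(Br)n3)cc2)n2nc(SCc3ccc(Cl)cc3)nc2n1`: 90.2%
- compound 2, `Cc1cc(Nc2ccc(C(=O)/C=C/c3cccc(Br)n3)cc2)n2nc(SCc3ccc(Br)cc3)nc2n1`: 96.3%
- compound 3, `Cc1cc(Nc2ccc(C(=O)/C=C/c3cccc(Br)n3)cc2)n2nc(SCc3ccc([N+](=O)[O-])cc3)nc2n1`: 91.6%

Compound 3 stands close to both others: the step of a number 1.4 percentage points higher from compound 1 to compound 3 (within the scatter) and the step of a number 4.7 percentage points lower from compound 2 to compound 3 (within the scatter) are each within the scatter, as is the step of a number 6.1 percentage points higher from compound 1 to compound 2 (within the scatter). For the measured compounds named here, the three values give no separation of the compounds in this assay; changing the group on the benzyl ring from chloro to bromo or to nitro leaves the read-out where it was.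

Compound 4, `Cc1cc(Nc2ccc(C(=O)/C=C/c3cccc(Br)n3)cc2)n2nc(SCc3ccccc3[N+](=O)[O-])nc2n1`, differs from compound 3 by 2-nitrophenyl in place of 4-nitrophenyl on a saturated chain carbon bound to a sulfur. Going by the values given here, none of the measured steps moves a group from one place on that ring to another; each only exchanges one group for another at the same place. The bearing they have is indirect: every variation at this end of the molecule so far stayed within the scatter, and nothing suggests that the new arrangement should behave otherwise. The expected step is therefore small, a number 3.6 percentage points lower from compound 3 to compound 4 (within the scatter), with no direction beyond the scatter. Compound 4 is estimated at 88%, with a range from 74% to 97%.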

Compound 4, a percentage reported as inhibition, at one concentration (the size of the read-out at that concentration, not a potency): 92.3%
Estimate against measurement, compound 4: 4.3 percentage points below; the range from low to high includes it.
By their numbers in this assay, from the lowest: compounds 1, 3, 4 and 2 (each within the scatter of the next).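

Moving the nitro group gives a number 0.7 percentage points higher from compound 3 to compound 4 (within the scatter) in this assay, so at this position on a saturated chain carbon bound to a sulfur, a change of place on the ring, and not only a change of group, leaves the read-out within the scatter. The 2-nitrophenyl group also stands level with the two halogen-bearing rings, with a number 4 percentage points lower from compound 2 to compound 4 (within the scatter) for the 4-bromophenyl comparison and a number 2.1 percentage points higher from compound 1 to compound 4 (within the scatter) for the 4-chlorophenyl comparison. No measurement on hand accounts for this flat result.

The compounds shown leave open whether any change at this end of the molecule moves the read-out, since all of them carry a substituted benzyl group. An amine or a carboxylic acid on that ring, or a longer chain in place of the benzyl group, remains an open test.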